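The source may report more compounds than this note shows. Statements on the series, on what has been measured and on what is new or still open speak of the compounds shown alone.

Measured in a functional assay on MCF7 cells (Homo sapiens) for inhibition, read by MTT assay, with a stated time of 72 h; on this read-out lower numbers stand for stronger inhibition and higher numbers for weaker inhibition:

- Compound 1 `C=CCc1ccc(OCc2c(Cl)cccc2Cl)c(-c2ccc(OCc3c(Cl)cccc3Cl)c(CC=C)c2)c1`: > 50000 nM (a limit)
- Compound 2 `C=CCc1ccc(OCc2ccc(Cl)cc2Cl)c(-c2ccc(OCc3ccc(Cl)cc3Cl)c(CC=C)c2)c1`: > 50000 nM (a limit)
- Compound 3 `C=CCc1ccc(OCc2ccc(Cl)cc2Cl)c(-c2ccc(O)c(CC=C)c2)c1`: 27400 nM

Compound 2 has no exact number, only the limit > 50000 nM. Compound 1 sits at this same limit. Compound 4 `C=CCc1ccc(O)c(-c2ccc(OCc3ccc(Cl)cc3Cl)c(CC=C)c2)c1`, not yet measured, differs from compound 2 as follows: hydrogen in place of 2,4-dichlorobenzyl on an oxygen on an aromatic ring. For the measured compounds named here, one measured step bears on this, the same kind of exchange: an at least 1.8-fold lower number from compound 2 to compound 3 (0.26 log units; that floor lies within the scatter). Its floor lies within the usual scatter, so it offers only weak evidence. A modest move towards a lower number in this assay is therefore expected, and the expected step is an at least 1.8-fold lower number from compound 2 to compound 4 (0.26 log units; that floor lies within the scatter). The estimated value for compound 4 is 27000 nM, with an expected range of 12000 nM to 50000 nM.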

Compound 4, half-maximal inhibitory concentration: 14700 nM
Beside the measured number, compound 4's estimate is 1.8-fold (0.26 log units) above it; low and high end bracket the measured number.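

In this assay, the exchange of (2,4-dichlorobenzyl)oxy for hydroxy now gives a step beyond the scatter (an at least 3.4-fold lower number from compound 2 to compound 4 (0.53 log units; beyond the scatter)), whereas the same exchange on the other oxygen gave only a floor within it. This oxygen therefore tolerates losing the 2,4-dichlorobenzyl group, and the number falls when it goes. From the compounds shown here alone, the true size stays unknown because compound 2 has only a limit: (the limit of > 50000 nM in this assay, at which 2 of the 4 values shown sit).

Going by these compounds, whether the free hydroxy itself matters stays open. A methyl ether, or an amine or carboxylic acid on a short chain at this oxygen, could tell.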